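The source may hold more compounds than are shown below. What is called first, only, known or untested is meant among the compounds shown, and "the series" means these compounds.

Measured compounds:
compound 1 `COc1ccccc1N1CCN(CC(=O)N2CCN(c3nnc(-c4ccccc4)c(-c4ccccc4)n3)CC2)CC1` gives 444000 nM in an ADME assay on NIH3T3 cells (Mus musculus) for cytotoxicity, read by MTT assay, with a stated time of 24 h; a lower number here means a stronger inhibitor, a higher number a weaker inhibitor
compound 2 `O=C(CN1CCN(c2cccc(Cl)c2)CC1)N1CCN(c2nnc(-c3ccccc3)c(-c3ccccc3)n2)CC1` gives 178000 nM in this assay

Among the two measured compounds, compound 2 shows the lowest number in this assay; its nearest neighbour is compound 1, and the step of a 2.5-fold lower number from compound 1 to compound 2 (0.40 log units; beyond the scatter) shows that the two differ by more than the usual scatter. Compound 3 `COc1ccc(N2CCN(CC(=O)N3CCN(c4nnc(-c5ccccc5)c(-c5ccccc5)n4)CC3)CC2)cc1` has not yet been measured. It differs from compound 2 in one place: 4-methoxyphenyl in place of 3-chlorophenyl on an amine nitrogen in a ring. For the measured compounds named here, only one measured step bears on this change, namely a 2.5-fold lower number from compound 1 to compound 2 (0.40 log units; beyond the scatter), in which a methoxyphenyl group gave way to the chlorophenyl group and the number fell by a modest amount. Compound 3 brings a methoxyphenyl group back, though attached at a different position of the ring, so the most that can be drawn from the data is a modest rise in this assay, with the value expected to fall between those of compound 2 and compound 1. The expected step is a 1.7-fold higher number from compound 2 to compound 3 (0.23 log units; within the scatter). Compound 3 is therefore estimated at 300000 nM, with a range from 150000 nM to 600000 nM.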

Compound 3, half-maximal inhibitory concentration: > 910000 nM
Compound 3: only a limit was reported; the forecaster's own chance of this, stated with the estimate: 20%; middle value at least 3.0-fold (0.48 log units) away from the limit.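

Compound 3 gave only a limit in this assay, not an exact number: the limit of > 910000 nM in this assay, at which 1 of the 3 values shown sits.

Even so, the limit is enough to show that the two methoxyphenyl compounds are not interchangeable, since replacing 2-methoxyphenyl with 4-methoxyphenyl on the ring amine nitrogen gives an at least 2.0-fold higher number from compound 1 to compound 3 (0.31 log units; beyond the scatter); compound 1 alone had suggested only how one methoxyphenyl group compares with 3-chlorophenyl, whereas this pair shows that the numbered location of the methoxy group on the phenyl ring also matters. Replacing 3-chlorophenyl with 4-methoxyphenyl gives an at least 5.1-fold higher number from compound 2 to compound 3 (0.70 log units; beyond the scatter), a change that is also beyond the scatter and can be larger than the modest one first seen at this site, with the true size of both new steps remaining unknown.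

The compounds shown cannot separate the effect of the substituent from that of its location, as chlorine and methoxy never share a numbered location here; 3-methoxyphenyl and 4-chlorophenyl would fill that gap directly. As far as these compounds go, it also remains open how plain phenyl, or a phenyl ring carrying a carboxylic acid or an amine, would behave at this site.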